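The source may report more compounds than this note shows. Statements on the series, on what has been measured and on what is new or still open speak of the compounds shown alone.

Measured in an ADME assay on NHDF cells (Homo sapiens) for cytotoxicity, read by MTT assay, with a stated time of 72 h; a lower number here means a stronger inhibitor, a higher number a weaker inhibitor:
- compound 1 `COc1ccc(/C=C2\CCC/C(=C\c3cccc(Cl)c3)C2=O)cc1OC`: 11900 nM
- compound 2 `COc1ccc(/C=C2\CCC/C(=C\c3ccc(Cl)cc3)C2=O)cc1OC`: 11200 nM
- compound 3 `COc1ccc(/C=C2\CCC/C(=C\c3ccc(OC)c(OC)c3)C2=O)cc1`: 30900 nM

Compound 3 carries the highest number of the three, clear of both others by more than the scatter. The next analogue, compound 4 `COc1ccc(/C=C2\CCC/C(=C\c3cc(Cl)cc(Cl)c3)C2=O)cc1OC`, differs from it as follows: 3,5-dichlorophenyl in place of 4-methoxyphenyl on a double-bonded chain carbon bound to a double-bonded ring carbon.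

Among the measured compounds shown here, two measured steps bear most directly on this change: a 2.6-fold higher number from compound 1 to compound 3 (0.41 log units; beyond the scatter), and a 2.8-fold higher number from compound 2 to compound 3 (0.44 log units; beyond the scatter). Both are modest, and both show that the compounds with a chlorinated ring on this carbon have lower numbers than compound 3. A third step, a 1.1-fold lower number from compound 1 to compound 2 (0.03 log units; within the scatter), shows no change beyond the scatter when the chloro group takes a different place on the ring. For the measured compounds named here, no measured compound carries the 3,5-dichlorophenyl group, so its value can only be inferred from the single-chloro compounds, and the series is small. The working expectation is that compound 4 lands near compound 1 and compound 2, with the number moving down by about the size of those two modest steps.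

The expected change is a 3.1-fold lower number from compound 3 to compound 4 (0.49 log units; beyond the scatter). For compound 4 the estimated value is 10000 nM, with an expected range of 5000 nM to 20000 nM.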

Compound 4, half-maximal inhibitory concentration: 8300 nM
For compound 4 the middle estimate is 1.2-fold (0.08 log units) above the measured one; the measured number falls inside the stated range.
By their numbers in this assay, from the lowest: compounds 4, 2 and 1 (each within the scatter of the next); then compound 3.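

In this assay, chloro in place of hydrogen on the aromatic ring leaves the number within the scatter, with a 1.4-fold lower number from compound 1 to compound 4 (0.16 log units; within the scatter), and the full exchange of 4-chlorophenyl for 3,5-dichlorophenyl does the same, with a 1.3-fold lower number from compound 2 to compound 4 (0.13 log units; within the scatter); the number of chloro groups on this ring therefore does not separate these compounds, a point the single-chloro pair could not address. The exchange of 4-methoxyphenyl for 3,5-dichlorophenyl is beyond the scatter, with a 3.7-fold lower number from compound 3 to compound 4 (0.57 log units; beyond the scatter), so the modest gap seen with the single-chloro compounds also holds for the dichloro ring. No supporting data bear on the reason for these differences.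

Still open, from the compounds shown here alone, is whether an amine or a carboxylic acid on this ring would move the number clear of the band held by compounds 1, 2 and 4. Also open, going by these compounds, is how far that band depends on the 3,4-dimethoxyphenyl group held constant in those three compounds.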